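The source may report more compounds than this note shows. Statements on the series, on what has been measured and on what is new or still open speak of the compounds shown alone.

Measured compounds:
- compound 1 `CCOC(=O)C1CCN(C(=O)CN2CN(c3ccccc3)C3(CCN(C(=O)c4ccc(C(C)(C)C)cc4)CC3)C2=O)CC1` — 3100 nM
- compound 2 `CCc1nn(CC)c(C2CCN(C(=O)CN3CN(c4ccccc4)C4(CCN(C(=O)c5ccc(C(C)(C)C)cc5)CC4)C3=O)CC2)c1C` — 2500 nM

In an assay on HEK293 cells for displacement of a labelled ligand from NPC1-like intracellular cholesterol transporter 1 (Homo sapiens) (on this read-out lower numbers stand for stronger inhibition and higher numbers for weaker inhibition), compound 1 gives 3100 nM, the higher of the two numbers; its nearest neighbour is compound 2, and a 1.2-fold lower number from compound 1 to compound 2 (0.09 log units; within the scatter), so the two are not separated on this assay.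

Compound 3 `CCOC(=O)C1CCCN(C(=O)CN2CN(c3ccccc3)C3(CCN(C(=O)c4ccc(C(C)(C)C)cc4)CC3)C2=O)C1` has not yet been measured. It differs from compound 1 in one place: 3-(ethoxycarbonyl)piperidin-1-yl in place of 4-(ethoxycarbonyl)piperidin-1-yl on a carbonyl carbon. The group itself is unchanged; only its point of attachment on the saturated ring moves.

Among the compounds with values here, only one measured step touches this part of the molecule. From compound 1 to compound 2 the whole ethoxycarbonyl was exchanged for a 1,3-diethyl-4-methyl-1H-pyrazol-5-yl, a far larger change than moving the ester along the ring, and still a 1.2-fold lower number from compound 1 to compound 2 (0.09 log units; within the scatter). Since that large exchange left the number within the scatter, the smaller rearrangement in compound 3 is expected to do no more, in either direction.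

Compound 3 is therefore estimated at 3000 nM in this assay, with a range from 1200 nM to 8000 nM, which means an expected 1.0-fold lower number from compound 1 to compound 3 (0.01 log units; within the scatter).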

Compound 3, half-maximal inhibitory concentration: 8200 nM
Compound 3: middle estimate off by 2.7-fold (0.44 log units), on the low side, outside the stated range (above it).
By their numbers in this assay, from the lowest: compounds 2 and 1 (each within the scatter of the next); then compound 3.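

In this assay, where the ester sits on the saturated ring matters: moving it gives a 2.6-fold higher number from compound 1 to compound 3 (0.42 log units; beyond the scatter) even though the two compounds have the same atoms, and the counts of rings, donors and acceptors in the two groups are the same. The earlier exchange of the whole ester for 1,3-diethyl-4-methyl-1H-pyrazol-5-yl gave only a 1.2-fold lower number from compound 1 to compound 2 (0.09 log units; within the scatter) and so made this part of the molecule look tolerant, but these three compounds show that the point of attachment can count for more than the identity of the group. Nothing measured here explains why the shift weakens inhibition.

The compounds shown leave open whether the loss follows the attachment point whatever group is carried, since 1,3-diethyl-4-methyl-1H-pyrazol-5-yl appears only in compound 2, with the attachment of compound 1. They also leave open how a carboxylic acid or a primary amide in place of the ethyl ester would behave at either attachment point on the ring.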